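Trifluoromethoxy for fluoro on the shared core

A few compounds are considered here, and "the series" means these few. Any claim that something is new, unique, unknown or untested is made for them only; others in the source may bear on it.

The series shares one core, carried by compound 1 `Oc1ccccc1-c1cc(-c2ccccc2F)cc(-c2ccccc2O)n1`. In a functional assay on T47D cells (Homo sapiens) for inhibition (a lower number here means a stronger inhibitor, a higher number a weaker inhibitor), compound 1 gives > 50000 nM, which is a limit of the assay and not a number. Compound 2 `Oc1ccccc1-c1cc(-c2cccc(F)c2)cc(-c2ccccc2O)n1` carries 3-fluorophenyl in place of 2-fluorophenyl on an aromatic carbon; in this assay compound 2 gives > 50000 nM, again a limit. Compound 3 `Oc1ccc(-c2cc(-c3ccccc3F)cc(-c3ccccc3O)n2)cc1` carries 4-hydroxyphenyl in place of 2-hydroxyphenyl on an aromatic carbon; in this assay compound 3 gives > 50000 nM, also a limit. The step that the two limits leave unreadable from compound 1 to compound 2 and the step that the two limits leave unreadable from compound 1 to compound 3 therefore carry no readable size, and the whole picture of the series rests on (the limit of > 50000 nM in this assay, at which 3 of the 3 values shown sit).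

Compound 4 `Oc1ccccc1-c1cc(-c2ccccc2OC(F)(F)F)cc(-c2ccccc2O)n1` is not yet measured. It differs from compound 1 by trifluoromethoxy in place of fluoro on an aromatic carbon. Both measured steps that leave compound 1 bear on this change, and neither gives a direction or a size that could be carried over. None of the three values points to anything below the limit. For compound 4 in this assay the estimate is 50000 nM, with a range from 15000 nM to 200000 nM. The step of a number no higher from compound 1 to compound 4 (the limit leaves the size open) that this estimate implies is expected to be none beyond the scatter.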

Compound 4, half-maximal inhibitory concentration: 1730 nM
Estimate against measurement, compound 4: 29-fold (1.46 log units) above; measured number outside the range, below it.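

In this assay, within the data shown here, trifluoromethoxy in place of fluoro gives an at least 28-fold lower number from compound 1 to compound 4 (1.46 log units; beyond the scatter), the only step with a readable size, as the two earlier steps from compound 1 cannot be read. This shows that the aromatic carbon ortho to a large group, on the ring that carries fluoro in compound 1, is a place where a change of group can bring a compound of this series off the limit. Compound 4 gives 1730 nM, a true number that later changes can be compared against. The rest of the series stays at a limit of the assay, so the activity seen here rests on this single change: the limit of > 50000 nM in this assay, at which 3 of the 4 values shown sit.

Still open, going by these compounds, is whether the gain is tied to trifluoromethoxy itself, since methoxy, trifluoromethyl or an amine at the same place could each give a different answer. Also open, on these data alone, are the full size of the step, which starts from a limit, and whether trifluoromethoxy elsewhere on the shared core would lower the number in the same way.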